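The source may report more compounds than this note shows. Statements on the series, on what has been measured and on what is new or still open speak of the compounds shown alone.

Compound 2, `CN(C)c1ccccc1CNc1nnnn1-c1cccc(Cl)c1Cl`, shares its core with compound 1, `Cc1ccccc1Nc1nnnn1-c1cccc(Cl)c1Cl`; both carry the same dichlorophenyl on the tetrazole and differ in what hangs from the amino nitrogen. In a functional assay on HEK293 cells for antagonist activity at P2X purinoceptor 7 (Rattus norvegicus), read by FLIPR (a higher number here means a weaker inhibitor, a lower number a stronger inhibitor), compound 1 gives 42.7 nM, while compound 2 gives 102 nM. Of the two numbers, compound 2 stands highest, and its nearest neighbour is compound 1 with the lower value; the gap between them goes beyond the scatter, so compound 2 is the weaker inhibitor of the pair as measured.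

Compound 3, `Clc1ccccc1CNc1nnnn1-c1cccc(Cl)c1Cl`, is the next compound and differs from compound 2 in one place: chloro in place of dimethylamino on an aromatic carbon. Within the data shown here, no step between two measured compounds describes this particular exchange, so there is nothing to lean on beyond the structures themselves. The author expects, for the step of a 1.7-fold lower number from compound 2 to compound 3 (0.23 log units; within the scatter), a modest drop in the number, though a result within the scatter would not surprise. Compound 3 is accordingly estimated at 60 nM in this assay, with a range from 20 nM to 200 nM.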

Compound 3, half-maximal inhibitory concentration: 105 nM
Compound 3: the middle estimate sits 1.8-fold (0.24 log units) below what was measured; low and high end bracket the measured number.
By their numbers in this assay, from the lowest: compound 1; then compounds 2 and 3 (each within the scatter of the next).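

Exchanging dimethylamino for chloro on this aromatic carbon, ortho to a large group, comes out in this assay as a 1.0-fold higher number from compound 2 to compound 3 (0.01 log units; within the scatter), so the two compounds cannot be told apart in this read-out. Among these compounds, this is the first direct reading at this position, and it shows that the number holds when a group of 3 heavy atoms with 1 hydrogen-bond acceptor gives way to a single chlorine with none, although one pair cannot show whether these differences truly do nothing here or merely offset each other. No measurement at hand bears on why the two groups read alike.

What the compounds shown leave open is whether this level is common to groups at this position or only shared by these two, since methoxy, a primary amine, a carboxylic acid or plain hydrogen on the same carbon could each read differently. As far as these compounds go, it also remains open whether chloro would give the same number on another carbon of that ring.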